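The compounds below may be only part of what the source reports. "The series", "measured", "known", "first", "only" and "open" are said of these compounds alone.

Three anilides sharing a two-armed amide scaffold have been compared in an assay on isolated protein for inhibition of Rho-associated protein kinase 1 (Homo sapiens), read by scintillation counting, radiometric assay and 33P incorporation, with a stated time of 40 min, in the presence of a further agent that is not named here; a lower number here means a stronger inhibitor, a higher number a weaker inhibitor. Compound 3 `CC(=O)Nc1cccc(NC(=O)COc2ccc3c(=O)ccoc3c2)c1` gives 2500 nM in this assay, the highest of the two numbers; its nearest neighbour, compound 1 `CN(C)c1ccc(C(=O)Nc2cccc(NC(=O)COc3ccc4c(c3)OCCC4=O)c2)cc1`, gives 144 nM in this assay. Compound 2 `CN(C)c1ccc(C(=O)Nc2cccc(NC(=O)COc3ccc4occc(=O)c4c3)c2)cc1` gives > 10000 nM in this assay, a limit of the assay rather than a number, which is the limit of > 10000 nM in this assay, at which 1 of the 3 values shown sits. Within the data shown here, the single measured step, an at least 69-fold higher number from compound 1 to compound 2 (1.84 log units; beyond the scatter), changes the ether-linked ring system and leaves the amide untouched. Compound 4 `O=C(COc1ccc2c(=O)ccoc2c1)Nc1cccc(NC(=O)c2cccc([N+](=O)[O-])c2)c1` differs from compound 3 by 3-nitrophenyl in place of methyl on a carbonyl carbon. Among the measured compounds shown here, no measured step bears on that position, so no direction can be drawn from the data. Compound 4 is therefore expected to give about 3000 nM, between 700 nM and 12000 nM, an expected step of a 1.2-fold higher number from compound 3 to compound 4 (0.08 log units; within the scatter) within the scatter.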

Compound 4, half-maximal inhibitory concentration: 528 nM
Compound 4: middle estimate off by 5.7-fold (0.75 log units), on the high side; measured number outside the range, below it.
By their numbers in this assay, from the lowest: compound 1; then compound 4; then compound 3. At a limit, above all of these: compound 2.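

In this assay, among these compounds, the carbonyl carbon whose other neighbour is the amide-type nitrogen now has a measured step, which the earlier compounds did not provide: 3-nitrophenyl in place of methyl gives a 4.7-fold lower number from compound 3 to compound 4 (0.68 log units; beyond the scatter). This position therefore responds to its group, and here the larger replacement lowers the number rather than raising it. Nothing measured here accounts for this change. The compounds shown leave open whether the nitro group or the ring carries the step, and how an unsubstituted phenyl, a carboxylic acid or a longer alkyl chain would read at this position.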